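Ring-fused pyrazole with an ether oxygen: expected lipophilicity

The source may report more compounds than this note shows. Statements on the series, on what has been measured and on what is new or still open speak of the compounds shown alone.

Three compounds share a core and differ only in the pyrazole-bearing part and the halogen. Compound 2 `CC(=O)N[C@@H]1CCC[C@H](C(=O)Nc2cc(-c3cnn(C)c3C)c(Cl)cn2)C1` gives 2.6 in a physicochemical assay for lipophilicity, using the shake flask method, measured as octanol-water partition, at pH 7.4 (on this read-out lower numbers stand for lower lipophilicity and higher numbers for higher lipophilicity), the lowest of the three values. Compound 1 `CC(=O)N[C@@H]1CCC[C@H](C(=O)Nc2cc(-c3cnn4c3CCCC4)c(F)cn2)C1` gives 2.9 in this assay, within the scatter of compound 2, and compound 3 `CC(=O)N[C@@H]1CCC[C@H](C(=O)Nc2cc(-c3cnn4c3CCCCC4)c(Cl)cn2)C1` gives 3.6, clearly higher.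

Compound 4 `CC(=O)N[C@@H]1CCC[C@H](C(=O)Nc2cc(-c3cnn4c3COCC4)c(Cl)cn2)C1` is not yet measured. Compared with compound 2 it carries a group of 9 heavy atoms (6 carbon, 2 nitrogen, 1 oxygen; one five-membered aromatic ring with 2 hetero atoms, one six-membered non-aromatic ring with 2 hetero atoms) in place of a group of 7 heavy atoms (5 carbon, 2 nitrogen; one five-membered aromatic ring with 2 hetero atoms), on an aromatic carbon.

Among the compounds with values here, the one measured step that bears on this is the fusion of a saturated ring onto the pyrazole, where the step of a number 1.00 log units higher from compound 2 to compound 3 (beyond the scatter) was seen. Compound 4 also fuses a ring, but it is one atom smaller and holds an oxygen in place of a carbon, so the rise seen for compound 3 is not expected to carry over; a small fall is expected instead. The expected step for compound 4 is a number 0.30 log units lower from compound 2 to compound 4 (within the scatter). The estimate for compound 4 in this assay is 2.3, with a range from 1.8 to 2.8.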

Compound 4, distribution coefficient: 2.4
Estimate against measurement, compound 4: 0.10 log units below; the range from low to high includes it.
By their numbers in this assay, from the lowest: compounds 4, 2 and 1 (each within the scatter of the next, the first and the last beyond it); then compound 3.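

In this assay, putting the fused ring that holds an oxygen in place of the 1,5-dimethyl-1H-pyrazol-4-yl group gives a number 0.20 log units lower from compound 2 to compound 4 (within the scatter), so fusing a ring at this position does not have to bring the rise seen with compound 3. The two fused rings themselves lie far apart, with a number 1.20 log units lower from compound 3 to compound 4 (beyond the scatter), which shows that this read-out depends strongly on what the fused ring is built from. No measurement here explains why the numbers fall as they do.

Ring size and the oxygen change together between compound 3 and compound 4, so their separate shares stay unknown. A six-membered fused ring with a carbon or an amine nitrogen in place of the oxygen, keeping the chloro group, would help to separate them.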